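From 4-methoxythiophen-2-yl to 5-methoxythiophen-2-yl

The source may report more compounds than this note shows. Statements on the series, on what has been measured and on what is new or still open speak of the compounds shown alone.

This piece follows a single structural change, judged in a functional assay on MES-SA/Dx5 cells (Homo sapiens) for antiproliferative activity, with a stated time of 72 h; on this read-out higher numbers stand for weaker inhibition and lower numbers for stronger inhibition. In this assay compound 1 `COc1cc(/C=C\c2cc3cc(O)ccc3s2)cc(OC)c1OC` stands as "not determined" (no result reported). In the same way, compound 2 `COc1ccsc1/C=C\c1cc(OC)c(OC)c(OC)c1` stands as "not determined" (no result reported). Within the data shown here, that leaves compound 3 `COc1csc(/C=C\c2cc(OC)c(OC)c(OC)c2)c1`, at 27 nM, with the only number available, so it cannot yet be ranked against any other compound.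

Compound 4 `COc1ccc(/C=C\c2cc(OC)c(OC)c(OC)c2)s1` has the same atoms as compound 3, joined differently: 5-methoxythiophen-2-yl in place of 4-methoxythiophen-2-yl on a double-bonded chain carbon bound to a double-bonded chain carbon. Among the measured compounds shown here, no measured step between closely related compounds exists to show how much such a move matters here, so any forecast is a cautious judgement. The estimated step of a 2.6-fold higher number from compound 3 to compound 4 (0.41 log units; beyond the scatter) is a moderate weakening, expected to lie a little beyond the usual scatter. For compound 4 the estimate is 70 nM, with an expected range from 12 nM to 400 nM.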

Compound 4, half-maximal inhibitory concentration: 75 nM
Compound 4: middle estimate off by 1.1-fold (0.03 log units), on the low side; low and high end bracket the measured number.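

Among these compounds, replacing 4-methoxythiophen-2-yl with 5-methoxythiophen-2-yl, on a double-bonded chain carbon bound to a double-bonded chain carbon, gives the first comparison at this position in this assay: the change produces a 2.8-fold higher number from compound 3 to compound 4 (0.44 log units; beyond the scatter), a modest weakening. The two groups hold the same atoms and the same counts of hydrogen-bond donors and acceptors, so this pair shows that how those atoms are joined can by itself shift the read-out. Nothing available explains why this change has this effect.

On these data alone, it remains open whether an amine or a longer chain in place of the methoxy group on the thiophene would keep or lose strength. A single step also cannot show whether the same change would have a similar effect on another core.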